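Bromo to fluoro on the sulfonamide series

This account rests on a few compounds, and the source may have more. Where it says the series, first, only, none or still open, it means among the compounds named here.

Of the compounds shown here, two have been measured in a functional assay on MCF7 cells (Homo sapiens) for cytotoxicity; on this read-out lower numbers stand for stronger inhibition of growth and higher numbers for weaker inhibition of growth. Compound 1 `COc1ccc(NS(=O)(=O)c2c(F)c(F)c(F)c(Br)c2F)cc1` gives 270 nM, the lower of the two numbers, while compound 2 `COc1ccc(NS(=O)(=O)c2cc(F)c(Cl)c(F)c2F)cc1` gives 44000 nM, a gap well beyond the scatter. These two compounds differ in more than one place, so their gap gives no direct measure of a single halogen change.

The next compound is compound 3 `COc1ccc(NS(=O)(=O)c2c(F)c(F)c(F)c(F)c2F)cc1`, which is related to compound 1 by one change: fluoro in place of bromo on an aromatic carbon. Fluoro takes the place of bromo on an aromatic carbon, ortho to two fluoro groups and meta to a large group. The rest of the core of compound 1 is unchanged.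

For the measured compounds named here, no measured pair isolates this change, so the expectation rests on compound 1 at 270 nM and on the modest size of the swap. In this assay, a lean towards a slightly lower number is expected, but no step beyond the scatter. The expected change is a 1.4-fold lower number from compound 1 to compound 3 (0.13 log units; within the scatter). For compound 3 the estimated value is 200 nM, with an expected range of 60 nM to 700 nM.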

Compound 3, concentration for 50% growth inhibition: 29 nM
For compound 3 the middle estimate is 6.9-fold (0.84 log units) above the measured one; the whole stated range lies above it.
By their numbers in this assay, from the lowest: compound 3; then compound 1; then compound 2.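

Working note on this position: in this assay, the group on this aromatic carbon is far from silent, as fluoro in place of bromo gives a 9.3-fold lower number from compound 1 to compound 3 (0.97 log units; beyond the scatter) with the rest of the core of compound 1 unchanged. For the compounds shown here, this is the first step that isolates one change, and because it lies beyond the scatter, it shows that the read-out responds to which of these two halogens sits on this carbon, with fluoro on the side of the lower number. Nothing on hand bears on why the swap has this effect, and a single pair gives a direction for these two groups at this one place only.

Still open, on these data alone, is what an iodo, a methyl, a nitrile or an amine group would give on this same carbon, and so whether the read-out follows any order across such groups or simply favours fluoro here. Also open, as far as these compounds go, is whether the same swap at another aromatic carbon, or on a core with a carboxylic acid in place of the methoxy group, would give a step of similar size.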